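A new amino substituent on the chain of compound 2

This account rests on a few compounds, and the source may have more. Where it says the series, first, only, none or still open, it means among the compounds named here.

Measured compounds, with their values in a functional assay for inhibition, with Homo sapiens as the target (on this read-out higher numbers stand for weaker inhibition and lower numbers for stronger inhibition), as the read-out:
- compound 1 `CCCCS(=O)(=O)N[C@@H](CNC(=O)c1cc2sc(CCC3CCNCC3)cc2s1)C(=O)O` at 10 nM
- compound 2 `O=C(O)CCNC(=O)c1cc2sc(CCC3CCNCC3)cc2s1` at 500 nM

Compound 2 stands at 500 nM as the higher of the two numbers, which makes it the weaker inhibitor of the pair, and its gap to compound 1 lies beyond the scatter. Compound 3 `O=C(NCc1ccccc1)N[C@@H](CNC(=O)c1cc2sc(CCC3CCNCC3)cc2s1)C(=O)O` is built from compound 2 through one change: (benzylcarbamoyl)amino in place of hydrogen on a saturated chain carbon bound to a carbonyl carbon and a saturated chain carbon on the chain carbon that carries the (butylsulfonyl)amino group in compound 1.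

Among the compounds with values here, only one measured step bears on this. That step, a 50-fold higher number from compound 1 to compound 2 (1.70 log units; beyond the scatter), is large and comes from losing the (butylsulfonyl)amino group. Within the data shown here, compound 3 instead fills that place with (benzylcarbamoyl)amino, so a large move to lower numbers in this assay is expected, though no compound carrying this group has yet been measured. Among the measured compounds shown here, the estimated change is a 25-fold lower number from compound 2 to compound 3 (1.40 log units; beyond the scatter) and it is expected to fall somewhat short of the one measured step. Compound 3 is expected at 20 nM within an estimated range of 5 nM to 100 nM in this read-out.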

Compound 3, half-maximal inhibitory concentration: 36 nM
Estimate against measurement, compound 3: 1.8-fold (0.26 log units) below; the range from low to high includes it.
By their numbers in this assay, from the lowest: compound 1; then compound 3; then compound 2.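

In this assay, placing (benzylcarbamoyl)amino on the saturated chain carbon bound to a carbonyl carbon and a saturated chain carbon gives a 14-fold lower number from compound 2 to compound 3 (1.14 log units; beyond the scatter) and shows that a large step at this place is not confined to the (butylsulfonyl)amino group of compound 1. The two substituents are still not interchangeable, since replacing butylsulfonyl with benzylcarbamoyl on the amine nitrogen gives a 3.6-fold higher number from compound 1 to compound 3 (0.56 log units; beyond the scatter) and leaves compound 1 with the lowest number of the three. No measurement in hand accounts for either step.

The exchange between compound 1 and compound 3 alters the link to the nitrogen and the carbon group on it together, so a benzylsulfonyl or a butylcarbamoyl group on that nitrogen would be needed to tell the two parts apart. Going by these compounds, it also remains open how a plain amine would read at this chain carbon, which would show what the bare nitrogen contributes, and how the read-out would respond if a methyl ester replaced the carboxylic acid.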